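Ethoxy in Place of Phenyl: One Step Further

The source may hold more compounds than are shown below. What is called first, only, known or untested is meant among the compounds shown, and "the series" means these compounds.

Compound 1 `Oc1ccc(NC(=S)Nc2ccc3[nH]ccc3c2)cc1`: 41.5%
Compound 2 `O=C(c1ccccc1)c1ccc(NC(=S)Nc2ccc3[nH]ccc3c2)cc1`: 79.1%

In an ADME assay on isolated protein for inhibition of peroxidase (Raphanus sativus), read by fluorescence and Amplex Red, tested at 5 uM (a lower number here means a stronger effect, a higher number a weaker effect of the compound at the concentration tested), compound 2 gives 79.1%, the highest of the two numbers; the nearest is compound 1 with 41.5%. Compound 3 `CCOC(=O)c1ccc(NC(=S)Nc2ccc3[nH]ccc3c2)cc1` differs from compound 2 by ethoxy in place of phenyl on a carbonyl carbon. Among the measured compounds shown here, the single measured step, a number 37.6 percentage points higher from compound 1 to compound 2 (beyond the scatter), touches a different part of the molecule and bears only loosely on this change, yet it shows that alterations there can move the number greatly. Compound 3 is therefore expected to give back part of that rise, an estimated step of a number 14.1 percentage points lower from compound 2 to compound 3 (beyond the scatter), with an expected value of 65% and a range from 45% to 85%.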

Compound 3, a percentage reported as activity, at one concentration (the size of the read-out at that concentration, not a potency): 65.8%
Compound 3: middle estimate off by 0.8 percentage points, on the low side, and the stated range covers the measured number.
By their numbers in this assay, from the lowest: compound 1; then compound 3; then compound 2.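

Ethoxy in place of phenyl on the carbonyl carbon gives a number 13.3 percentage points lower from compound 2 to compound 3 (beyond the scatter), so the reading depends on what that carbonyl carbon carries and not on the carbonyl alone. Ethoxycarbonyl in place of hydroxy on the aromatic carbon still gives a number 24.3 percentage points higher from compound 1 to compound 3 (beyond the scatter), which leaves both compound 2 and compound 3 with a weaker effect than compound 1. No measurement at hand gives a reason for either step.

On these data alone, whether an amine on that carbonyl carbon, or a longer chain in place of ethoxy, would bring the number closer to that of compound 1 remains open. So does the effect of a carboxylic acid in place of ethoxycarbonyl.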